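Pyrazole nitrogen substitution in the methylurea amide series

The source may hold more compounds than are shown below. What is called first, only, known or untested is meant among the compounds shown, and "the series" means these compounds.

The measured pair is compound 1 `CNC(=O)N1CCCc2ccc(NC(=O)c3ccc(-c4cc[nH]n4)cc3)cc21` and compound 2 `CNC(=O)N1CCCc2ccc(NC(=O)c3ccc(-c4cn[nH]c4)cc3)cc21`. In a functional assay on MV4-11 cells (Homo sapiens) for antiproliferative activity, with a stated time of 6 days, tested at 1.56 uM (a higher number here means a stronger effect of the compound at the concentration tested, a lower number a weaker effect), compound 1 gives 92.5%, and compound 2 gives 73.5%. Within the data shown here, the one step between them, a number 19 percentage points lower from compound 1 to compound 2 (beyond the scatter), places compound 2 at the lower of the two numbers, with compound 1 as its only neighbour. Compound 3 `CNC(=O)N1CCCc2ccc(NC(=O)c3ccc(-c4cnn(S(C)(=O)=O)c4)cc3)cc21` has not been measured; it differs from compound 2 by methylsulfonyl in place of hydrogen on an aromatic nitrogen. Among the measured compounds shown here, no measured step touches the pyrazole nitrogen, so the only step available, the regiochemistry change from compound 1 to compound 2, does not bear directly on this substitution. With nothing to point either way, the expected step of a number 8.5 percentage points lower from compound 2 to compound 3 (within the scatter) is none beyond the scatter. Compound 3 is therefore estimated in this assay at 65%, with a range from 30% to 90%.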

Compound 3, a percentage reported as inhibition, at one concentration (the size of the read-out at that concentration, not a potency): 4.5%
For compound 3 the middle estimate is 60.5 percentage points above the measured one; measured number below the stated range.
By their numbers in this assay, from the lowest: compound 3; then compound 2; then compound 1.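

In this assay, the aromatic nitrogen of the pyrazole turns out to be far less forgiving than the attachment point on the ring: methylsulfonyl in place of hydrogen gives a number 69 percentage points lower from compound 2 to compound 3 (beyond the scatter), a large step, whereas the change of attachment alone gave only the modest a number 19 percentage points lower from compound 1 to compound 2 (beyond the scatter). Measured against the best compound of the series, the change reads as a number 88 percentage points lower from compound 1 to compound 3 (beyond the scatter), which leaves compound 3 with little effect at 4.5% at the concentration tested. Nothing available explains the size of this loss.

From the compounds shown here alone, whether a methyl or an acetyl on the same nitrogen would track with hydrogen or with methylsulfonyl stays open, so the loss cannot yet be assigned to substitution as such or to this one group. The same question stands for the nitrogen of the 1H-pyrazol-3-yl ring of compound 1.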